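Paw edema inhibition: methoxy for methyl on a shared core

The source may hold more compounds than are shown below. What is called first, only, known or untested is meant among the compounds shown, and "the series" means these compounds.

Measured compounds:
compound 1 `COc1ccc(-c2nn(-c3ccc(Cl)cc3)cc2-c2cc(-c3ccc(Cl)cc3)[nH]c2-c2ccc(F)cc2)cc1` gives 61.9%
compound 2 `Cc1ccc(-c2nn(-c3ccc(S(N)(=O)=O)cc3)cc2-c2cc(-c3ccc(Cl)cc3)[nH]c2-c2ccc(F)cc2)cc1` gives 66.7%

Of the compounds shown here, two on a shared core have been tested in a functional assay on the whole organism (strain Wistar albino) for inhibition, with Rattus norvegicus as the target, read by paw edema, with stated times of 1 h and 3 h, at a dose of 0.32 mmol/kg by the intraperitoneal route; a lower number here means less inhibition, a higher number more inhibition at the dose given (going by the name of the read-out). Compound 2 has the higher of the two numbers, yet the gap to compound 1 is within the scatter, so the two cannot be told apart on these data.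

Compound 3 `COc1ccc(-c2nn(-c3ccc(S(N)(=O)=O)cc3)cc2-c2cc(-c3ccc(Cl)cc3)[nH]c2-c2ccc(F)cc2)cc1` has not yet been measured. It is derived from compound 2 by one change: methoxy in place of methyl on an aromatic carbon. The methyl leaves and a methoxy enters on an aromatic carbon, para to a large group; the same methoxy already sits in compound 1, where it gave a number in the same band as compound 2.

Among the measured compounds shown here, no step between measured compounds is available, so the change is expected to give a step of a number 2.7 percentage points lower from compound 2 to compound 3 (within the scatter), that is, none beyond the scatter. Compound 3 is therefore expected to reach about 64%, within a range of 52% to 76% in this assay.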

Compound 3, a percentage reported as inhibition, in the whole organism at one dose (the size of the read-out at that dose, not a potency): 55.9%
Estimate against measurement, compound 3: 8.1 percentage points above; the range from low to high includes it.
By their numbers in this assay, from the lowest: compounds 3, 1 and 2 (each within the scatter of the next, the first and the last beyond it).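

Within this assay, changing 4-methylphenyl to 4-methoxyphenyl gives a number 10.8 percentage points lower from compound 2 to compound 3 (beyond the scatter), the first reading of this change alone, since compound 1 and compound 2 differ in two places at once. The read-out therefore responds, modestly, to what sits at this position on the aromatic ring. With the methoxy held fixed, sulfamoyl in place of chloro gives a number 6 percentage points lower from compound 1 to compound 3 (within the scatter), so this second exchange shows no separable effect, and nothing available explains either step.

As far as these compounds go, it remains open whether the methyl-to-methoxy step would have the same size with chloro in place of sulfamoyl. From the compounds shown here alone, how a hydroxyl, an amine or a longer chain such as ethoxy would read at this position also remains open.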